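This account rests on a few compounds, and the source may have more. Where it says the series, first, only, none or still open, it means among the compounds named here.

In an ADME assay on KB cells (Homo sapiens) for cytotoxicity; a lower number here means that less compound is needed, a higher number that more compound is needed for the effect:
- Compound 1 `Nc1nc(Cl)c2nnn(C3CC(O)C(CO)C3)c2n1`: 10 ug/mL
- Compound 2 `Nc1nc(O)c2nnn(C3CC(O)C(CO)C3)c2n1`: > 100 ug/mL
- Compound 3 `Nc1nc(N)c2ncn(C3CC(O)C(CO)C3)c2n1`: > 100 ug/mL

Compound 2 gives > 100 ug/mL, which is a limit and not a number. The change to compound 4 `Nc1nc(N)c2nnn(C3CC(O)C(CO)C3)c2n1` puts amino in place of hydroxy on an aromatic carbon. For the measured compounds named here, the one measured step at this carbon is an at least 10-fold higher number from compound 1 to compound 2 (1.00 log units; beyond the scatter). It ends at a limit, so it gives no exact size for a further change there. Compound 3, which carries amino at that place on a different core, gives > 100 ug/mL, again a limit. With this precedent, a clear drop in the number is not expected, and a number no higher from compound 2 to compound 4 (the limit leaves the size open) is the estimated step. Compound 4 is expected to give about 100 ug/mL, with an estimated range of 30 ug/mL to 300 ug/mL.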

Compound 4, concentration for half-maximal effect: > 100 ug/mL
Compound 4 gave a limit, no number (the forecaster's own chance of this, stated with the estimate: 65%); the middle value lies on the limit itself.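

In this assay, amino at this aromatic carbon gives the same kind of result as hydroxy when it replaces chloro: an at least 10-fold higher number from compound 1 to compound 4 (1.00 log units; beyond the scatter). On the shared core, compound 1 now stands apart from two replacements rather than one. The step from compound 2 to compound 4 cannot be read because both compounds sit at a limit and not at a number: the limit of > 100 ug/mL in this assay, at which 3 of the 4 values shown sit.

Going by these compounds, how far compound 2 and compound 4 lie beyond that limit stays open. So does whether bromo or methoxy at this carbon would keep a measurable number like that of compound 1.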